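Methyl Added to the Amine: From Compound 3 to Compound 4

The source may report more compounds than this note shows. Statements on the series, on what has been measured and on what is new or still open speak of the compounds shown alone.

compound 1, `COc1cc(Cl)ccc1Oc1ccncc1CN(C)C`: 10200 nM in an assay on HEK293 cells for inhibition of sodium-dependent dopamine transporter (Homo sapiens); on this read-out lower numbers stand for stronger inhibition and higher numbers for weaker inhibition
compound 2, `CCc1cc(Cl)ccc1Oc1ccncc1CNC`: "not determined" (no result reported) in this assay
compound 3, `CNCc1cnccc1Oc1ccc(Cl)cc1C`: "not determined" (no result reported) in this assay

Compound 3 stands without a number in this assay, and compound 2 is in the same position. The only figure in the set belongs to compound 1, which gives 10200 nM in this assay, a weak result. The step to compound 4, `Cc1cc(Cl)ccc1Oc1ccncc1CN(C)C`, is methyl in place of hydrogen on an amine nitrogen. Within the data shown here, no measured pair shows this change, so its size cannot be read from the data. Compound 1 already carries the dimethylamino group and differs from compound 4 only in the group on its other ring, so the result of compound 1, 10200 nM in this assay, is the nearest anchor. The expectation is therefore for no shift beyond the usual scatter in either direction from that anchor. On this basis compound 4 is expected to give 8000 nM in this assay, within a range from 2000 nM to 30000 nM.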

Compound 4, half-maximal inhibitory concentration: 3230 nM
Estimate against measurement, compound 4: 2.5-fold (0.39 log units) above, and the stated range covers the measured number.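

With compound 4, the set gains its first readable step in this assay: methyl in place of methoxy on an aromatic carbon gives a 3.2-fold lower number from compound 1 to compound 4 (0.50 log units; beyond the scatter), with the dimethylamino group shared by both compounds. Among these compounds, this shows that the number responds to the group on that aromatic carbon, which the single figure for compound 1 could not show, whereas the change from methylamino to dimethylamino on the amine nitrogen cannot be read, and compound 3 still has no number to set against compound 4. Nothing in the data gives a reason for the step.

The compounds shown leave open how fluorine or a propyl chain on that aromatic carbon would read. They also leave open how a diethylamino group would compare with the dimethylamino group of compound 4.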